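The source may report more compounds than this note shows. Statements on the series, on what has been measured and on what is new or still open speak of the compounds shown alone.

Measured so far:
- Compound 1 `O=c1cc(-c2ccccc2)oc2ccc(N3COc4c(cccc4[N+](=O)[O-])C3)cc12`: 61.9%
- Compound 2 `O=c1cc(-c2ccccc2)oc2cc(N3COc4c(Br)cccc4C3)ccc12`: 7.89%

Of the compounds shown here, two of the shared core have been tested in a functional assay on MCF7 cells (Homo sapiens) for inhibition, read by MTT assay, with a stated time of 48 h, tested at 30 ug/mL; a lower number here means less inhibition of growth, a higher number more inhibition of growth at the concentration tested. Compound 1 gives 61.9%, the highest of the two numbers. Its nearest neighbour, compound 2, gives 7.89%, a number that lies well beyond the usual scatter below compound 1. Going by the values given here, compound 2 differs from compound 1 in more than one place, so no single step between them can be read.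

Compound 3 `O=c1cc(-c2ccccc2)oc2ccc(N3COc4ccccc4C3)cc12` has not yet been measured in this assay. It differs from compound 1 in one place: hydrogen in place of nitro on an aromatic carbon. With no measured pair that isolates this change, the direction must be guessed from the two numbers shown. The nitro-free compound 2 is the weaker of the two, which suggests a loss of growth inhibition. Compound 3 is therefore expected to fall, with the step of a number 31.9 percentage points lower from compound 1 to compound 3 (beyond the scatter) estimated as a real drop beyond the scatter. The estimate for compound 3 is 30%, within a range of 5% to 60%.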

Compound 3, percent growth inhibition at one concentration: 68.5%
Compound 3: middle estimate off by 38.5 percentage points, on the low side, outside the stated range (above it).
By their numbers in this assay, from the lowest: compound 2; then compounds 1 and 3 (each within the scatter of the next).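

Hydrogen in place of nitro on this aromatic carbon gives a number 6.6 percentage points higher from compound 1 to compound 3 (within the scatter) in this assay. The nitro group is therefore not needed at this position for the growth inhibition seen at the concentration tested, since compound 3 carries only hydrogen there and its number cannot be told apart from that of compound 1. Nothing measured here explains why the exchange leaves the number within the usual scatter.

On these data alone, whether other groups on this aromatic carbon, such as an amine, a carboxylic acid or a longer chain, would also leave the number unchanged stays open. This single pair also cannot tell whether the same exchange would give the same result at another place on the shared core.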